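The compounds below may be only part of what the source reports. "The series", "measured", "known", "first", "only" and "open" are said of these compounds alone.

Working notes on the series. Two compounds share one core and differ only in the arrangement of methoxy and hydroxy on the pendant ring. In an assay on isolated protein for inhibition of Amine oxidase [flavin-containing] B (Homo sapiens) (a higher number here means a weaker inhibitor, a lower number a stronger inhibitor), compound 1 `COc1cc(/C=C2\COc3ccccc3C2=O)ccc1O` gives 105000 nM, the lower of the two numbers recorded so far. Compound 2 `COc1ccc(/C=C2\COc3ccccc3C2=O)cc1O` gives 479000 nM in this assay, a higher number than compound 1, and the gap between them lies beyond the usual scatter.

Compound 3 `Nc1cc(/C=C2\COc3ccccc3C2=O)ccc1O` is not yet measured. It differs from compound 1 by amino in place of methoxy on an aromatic carbon; the hydroxy group stays where it is, so only the group ortho to it changes. Among the compounds with values here, no measured pair shows an exchange of this kind, so nothing recorded here fixes the direction or size of the step. With the hydroxy group kept and the pendant ring otherwise unchanged, the expectation is a step from compound 1 to compound 3 of a 1.4-fold higher number from compound 1 to compound 3 (0.15 log units; within the scatter) in this assay, small and probably within the scatter, with the higher number slightly more likely than the lower. For compound 3 the estimate in this assay is 150000 nM, with a range from 40000 nM to 600000 nM.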

Compound 3, half-maximal inhibitory concentration: 479000 nM
The estimate for compound 3 lay 3.2-fold (0.50 log units) below the measured number; the range from low to high includes it.
By their numbers in this assay, from the lowest: compound 1; then compounds 2 and 3 (each within the scatter of the next).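

In this assay, the group ortho to a hydroxy group is not indifferent: amino in place of methoxy gives a 4.6-fold higher number from compound 1 to compound 3 (0.66 log units; beyond the scatter), with the pendant ring otherwise unchanged. Within the data shown here, this is the first single-place step, and it shows that this place alone can move the number beyond the scatter, with methoxy giving the lower number of this pair. The exchange alters the heavy-atom count and the hydrogen-bond donor count together, and nothing measured here explains the step.

On these data alone, a single pair cannot separate those two differences, so it remains open whether ethoxy, a plain hydrogen or a chlorine atom at this place would give a number nearer that of compound 1 or that of compound 3. As far as these compounds go, it is also open whether an acetamide or a dimethylamino group would follow amino, and whether the same exchange would give a step of similar size with the hydroxy group replaced by a methoxy group.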